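This account rests on a few compounds, and the source may have more. Where it says the series, first, only, none or still open, it means among the compounds named here.

Series notes. Compound 3 `O=C(N1CCCCC1)N1CCc2nc(C#Cc3ccccc3)sc2C1` gives 75 nM in an assay on HEK293 cells for positive allosteric modulation of metabotropic glutamate receptor 5 (Homo sapiens), read by FLIPR, with a stated time of 1 h (on this read-out higher numbers stand for an effect only at larger amounts of compound and lower numbers for an effect already at smaller amounts), and stands together with compound 2 `O=C(C1CC(F)C1)N1CCc2nc(C#Cc3ccccc3)sc2C1`, which gives 85 nM in this assay; a 1.1-fold lower number from compound 2 to compound 3 (0.05 log units; within the scatter), so the two numbers shown sit side by side. Compound 1 `O=C(C1CCC1)N1CCc2nc(C#Cc3ccccc3)sc2C1` reaches only a limit, > 10000 nM, in this assay. Compound 4 `O=C(N1CCC(F)CC1)N1CCc2nc(C#Cc3ccccc3)sc2C1` differs from compound 3 by fluoro in place of hydrogen on a saturated ring carbon. Among the compounds with values here, the one measured step of the same kind, an at least 110-fold lower number from compound 1 to compound 2 (2.07 log units; beyond the scatter), starts from the limit of > 10000 nM in this assay, at which 1 of the 3 values shown sits, and so fixes only a floor for its size; the same holds for an at least 130-fold lower number from compound 1 to compound 3 (2.12 log units; beyond the scatter). A lower number is therefore expected for compound 4, a 1.9-fold lower number from compound 3 to compound 4 (0.27 log units; within the scatter), though a smaller one than those floors. Compound 4 is estimated at 40 nM, within 10 nM to 200 nM.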

Compound 4, half-maximal effective concentration: 74 nM
Compound 4: the middle estimate sits 1.9-fold (0.27 log units) below what was measured, within the range that was stated.
By their numbers in this assay, from the lowest: compounds 4, 3 and 2 (each within the scatter of the next). At a limit, above all of these: compound 1.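

In this assay, fluoro on the saturated ring carbon three ring bonds from the ring nitrogen leaves piperidin-1-yl compounds level (a 1.0-fold lower number from compound 3 to compound 4 (0.01 log units; within the scatter)), so the size of this change depends on the group carrying it: the same change on two cores in this assay, an at least 110-fold lower number (2.07 log units; beyond the scatter) from compound 1 to compound 2 and a 1.0-fold lower number (0.01 log units; within the scatter) from compound 3 to compound 4, at least 110-fold (2.06 log units) apart, beyond the scatter of two such steps. The 4-fluoropiperidin-1-yl and 3-fluorocyclobutyl groups on the carbonyl carbon also cannot be told apart (a 1.1-fold lower number from compound 2 to compound 4 (0.06 log units; within the scatter)). Against the cyclobutyl group, the step (an at least 130-fold lower number from compound 1 to compound 4 (2.13 log units; beyond the scatter)) is only a floor, since it starts from a limit: the limit of > 10000 nM in this assay, at which 1 of the 4 values shown sits.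

From the compounds shown here alone, whether fluoro has any effect on other groups at the carbonyl carbon stays open. So does the behaviour of a hydroxyl or methoxy group on this ring carbon.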